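Flipping one double bond at the assay limit

The source may hold more compounds than are shown below. What is called first, only, known or untested is meant among the compounds shown, and "the series" means these compounds.

Values in a functional assay on HT-29 cells (Homo sapiens) for cytotoxicity; a lower number here means a stronger inhibitor, a higher number a weaker inhibitor:
Compound 1 `COC(=O)C[C@@H]1CCCN1CCC/C=C1\C=C(C)C(=O)O1`: > 5 ug/mL (a limit)
Compound 2 `COC(=O)C[C@H]1CCCN1CCC/C=C1\C=C(C)C(=O)O1`: > 5 ug/mL (a limit)

In this assay compound 2 gives > 5 ug/mL, which is a limit of the assay and not a number. Its true potency is therefore unknown, and the same holds for compound 1. Compound 3 `COC(=O)C[C@H]1CCCN1CCC/C=C1/C=C(C)C(=O)O1` changes one feature of compound 2: the two compounds have the same atoms and bonds and differ only in configuration as drawn: 1 of 2 stereo elements differ; a double bond is drawn E in compound 2 and Z in compound 3. Among the compounds with values here, the only measured step is a step that the two limits leave unreadable from compound 1 to compound 2, and it concerns a stereocentre at a saturated ring carbon, not the double bond. The guide it leaves is the limit of > 5 ug/mL in this assay, at which 2 of the 2 values shown sit, so no size of step can be read from it. No step beyond the usual scatter is expected, in either direction. The expected step is a step that the limit leaves unreadable from compound 2 to compound 3, an estimate only. For compound 3 the estimated value is 8 ug/mL, with an expected range from 4 ug/mL to 25 ug/mL.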

Compound 3, half-maximal inhibitory concentration: > 5 ug/mL
Compound 3 gave a limit, no number; the forecaster's own chance of this, stated with the estimate: 85%; the middle value does not contradict the limit.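

In this assay compound 3 gives > 5 ug/mL as a limit and not a number. Within the data shown here, compound 1 and compound 2 also stand at limits, so no step among the three can be read. From the compounds shown here alone, whether the stereocentre or the double bond configuration changes potency at all remains open.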